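An Amine Replaces the Phenoxy Group on the Side Chain

This account rests on a few compounds, and the source may have more. Where it says the series, first, only, none or still open, it means among the compounds named here.

Compound 3 `OC[C@H]1O[C@@H](n2cnc3c(COc4ccccc4)ncnc32)[C@H](O)[C@@H]1O` carries a phenoxy on a saturated chain carbon bound to an aromatic carbon. In a functional assay on Huh-7 cells (Homo sapiens) for cytotoxicity, read by MTT assay, with a stated time of 3 days (on this read-out lower numbers stand for higher toxicity in this test and higher numbers for lower toxicity in this test), compound 3 reaches only the limit > 100000 nM, so no number is known for it. Compound 1 `[N-]=[N+]=NCc1ncnc2c1ncn2[C@@H]1O[C@H](CO)[C@@H](O)[C@H]1O`, which has an azido at that place, likewise gives only the limit > 250000 nM. Compound 2 `CN(Cc1ccccc1)Cc1ncnc2c1ncn2[C@@H]1O[C@H](CO)[C@@H](O)[C@H]1O`, with benzyl(methyl)amino there, gives 9000 nM in this assay. The step of an at least 11-fold higher number from compound 2 to compound 3 (1.04 log units; beyond the scatter) shows that putting phenoxy in place of the amine carried the number past the limit, and an at least 27-fold lower number from compound 1 to compound 2 (1.44 log units; beyond the scatter) shows a large drop when the amine took the place of azido. Compound 4 `CC(C)N(Cc1ncnc2c1ncn2[C@@H]1O[C@H](CO)[C@@H](O)[C@H]1O)C(C)C` carries the change (diisopropylamino in place of phenoxy on a saturated chain carbon bound to an aromatic carbon). The two measured steps that bear on it are those involving the amine, an at least 11-fold higher number from compound 2 to compound 3 (1.04 log units; beyond the scatter) and an at least 27-fold lower number from compound 1 to compound 2 (1.44 log units; beyond the scatter), both large. Compound 4 again bears an amine at that place, though without the aromatic ring of compound 2, and because compound 2 gives 9000 nM with its amine, a large step to a lower number is expected, an at least 3.3-fold lower number from compound 3 to compound 4 (0.52 log units; beyond the scatter). Compound 4 is therefore estimated at 30000 nM, with a range from 8000 nM to 150000 nM.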

Compound 4, half-maximal cytotoxic concentration: 18000 nM
Beside the measured number, compound 4's estimate is 1.7-fold (0.22 log units) above it; the measured number falls inside the stated range.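

In this assay, a second amine confirms that the drop does not depend on the benzyl(methyl)amino of compound 2: an at least 5.5-fold lower number from compound 3 to compound 4 (0.74 log units; beyond the scatter), and an at least 13-fold lower number from compound 1 to compound 4 (1.14 log units; beyond the scatter). Diisopropylamino has no ring, yet a 2.0-fold higher number from compound 2 to compound 4 (0.30 log units; within the scatter), so in these two compounds the amine's aromatic ring is not needed to reach this level of toxicity. Compound 3 stands only at a limit, so the step from it gives a minimum size and not a true one: the limit of > 100000 nM in this assay, at which 1 of the 4 values shown sits.

On these data alone, it stays open whether a smaller amine such as dimethylamino would give a similar number on a saturated chain carbon bound to an aromatic carbon. A plain carbon chain such as pentyl at that place would test whether the amine nitrogen itself matters.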